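The compounds below may be only part of what the source reports. "The series", "measured", "known", "first", "only" and "open" are said of these compounds alone.

- Compound 1 `CC(C)(C)n1cc2c(n1)C(=O)CC1(CCN(C(=O)c3cc(-c4ccccc4Cl)nc4ccccc34)CC1)O2`: > 10000 nM
- Compound 2 `COc1ccc(-c2cc(C(=O)N3CCC4(CC3)CC(=O)c3nn(C(C)(C)C)cc3O4)c3ccccc3n2)cc1`: > 10000 nM
- Compound 3 `CC(C)(C)n1cc2c(n1)C(=O)CC1(CCN(C(=O)c3cc(-c4ccc(N)cc4)nc4ccccc34)CC1)O2`: 4960 nM

All three results come from a functional assay on MDA-MB-231 cells (Homo sapiens) for inhibition, read by MTT assay, with a stated time of 72 h; on this read-out higher numbers stand for weaker inhibition and lower numbers for stronger inhibition. Compound 1 and compound 2 both sit at the limit of > 10000 nM in this assay, at which 2 of the 3 values shown sit, which is a limit and not a number. Going by the values given here, compound 3, at 4960 nM, has the only true number so far.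

Compound 4 `CN(C)c1ccc(-c2cc(C(=O)N3CCC4(CC3)CC(=O)c3nn(C(C)(C)C)cc3O4)c3ccccc3n2)cc1` has dimethylamino in place of amino on an aromatic carbon. Among the compounds with values here, two measured steps bear on this change: an at least 2.0-fold lower number from compound 2 to compound 3 (0.30 log units; that floor lies within the scatter) and an at least 2.0-fold lower number from compound 1 to compound 3 (0.30 log units; that floor lies within the scatter). Both are only floors, and those floors lie within the scatter, so neither gives a firm size. Within the data shown here, no measured compound shows the effect of this exact swap, so no clear shift in this assay is expected. The expected change is a 1.2-fold higher number from compound 3 to compound 4 (0.08 log units; within the scatter), which would stay within the scatter. Compound 4 is estimated at 6000 nM, with an expected range of 2000 nM to 15000 nM.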

Compound 4, half-maximal inhibitory concentration: > 10000 nM
Compound 4: only a limit was reported; the forecaster's own chance of this, stated with the estimate: 35%; at least 1.6-fold (0.22 log units) between middle value and limit.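

In this assay compound 4 gives > 10000 nM, which is a limit and not a number: the limit of > 10000 nM in this assay, at which 3 of the 4 values shown sit. Replacing amino with dimethylamino gives an at least 2.0-fold higher number from compound 3 to compound 4 (0.30 log units; that floor lies within the scatter), a floor that lies within the scatter, so this position's tolerance for the larger group stays unsettled. The steps from compound 1 and compound 2 to compound 4 join two limits and cannot be read.

On these data alone, how far compound 4 lies past its limit remains open. So does whether a methylamino or acetamido group at this position would keep a measurable value.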